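One added hydroxy on compound 2

The source may report more compounds than this note shows. Statements on the series, on what has been measured and on what is new or still open speak of the compounds shown alone.

Measured so far in a functional assay on RAW264.7 cells (Mus musculus) for inhibition, read by Griess assay, with a stated time of 24 h (on this read-out higher numbers stand for weaker inhibition and lower numbers for stronger inhibition), for three compounds
compound 1 `C=C1[C@H](O)C[C@H]2[C@@](C)(CCC(=O)[C@@]2(C)CO)[C@@H]1CCC1=CCOC1=O` gives 58300 nM
compound 2 `C=C1CC[C@H]2[C@@](C)(CCC(=O)[C@@]2(C)CO)[C@@H]1CCC1=CCOC1=O` gives 10100 nM
compound 3 `C=C1CC[C@H]2[C@@](C)(CCC(=O)[C@@]2(C)CO)[C@@H]1/C=C/C1=CCOC1=O` gives 75300 nM

Compound 2 stands lowest of the three, and its gaps to both others lie beyond the scatter. Compound 4 `C=C1CC[C@H]2[C@@](C)([C@H](O)CC(=O)[C@@]2(C)CO)[C@@H]1CCC1=CCOC1=O` has hydroxy in place of hydrogen on a saturated ring carbon of compound 2. The closest guide is the step of a 5.8-fold lower number from compound 1 to compound 2 (0.76 log units; beyond the scatter) where hydrogen replaced a hydroxy on a different ring carbon. Read in reverse, it points to a higher number, though the place differs. The step of a 7.5-fold higher number from compound 2 to compound 3 (0.87 log units; beyond the scatter) involves another kind of change and says little here. A modest rise is therefore expected, with an estimated step of a 3.0-fold higher number from compound 2 to compound 4 (0.47 log units; beyond the scatter) in this assay for this change. Compound 4 is expected at 30000 nM with an estimated range from 11000 nM to 80000 nM in this assay.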

Compound 4, half-maximal inhibitory concentration: 61900 nM
Compound 4: the middle estimate sits 2.1-fold (0.31 log units) below what was measured; the measured number falls inside the stated range.
By their numbers in this assay, from the lowest: compound 2; then compounds 1, 4 and 3 (each within the scatter of the next).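

In this assay, hydroxy in place of hydrogen on this saturated ring carbon brings a 6.1-fold higher number from compound 2 to compound 4 (0.79 log units; beyond the scatter), so inhibition weakens at this position too. Together with a 5.8-fold lower number from compound 1 to compound 2 (0.76 log units; beyond the scatter), this means that on the shared core, hydrogen goes with the lower number at two different ring carbons, and no compound shown goes against that. Nothing available explains why the hydroxy has this effect. On these data alone, whether a methoxy group, a fluorine atom or an amine on this carbon would also raise the number remains open.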